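Benzyl urea analogue of a piperazine-linked amine series

The compounds below may be only part of what the source reports. "The series", "measured", "known", "first", "only" and "open" are said of these compounds alone.

Compound 2 `COc1ccc(-c2cnc3nc(N)nc(N4CCN(C(=O)Nc5ccc(C#N)cc5)CC4)c3n2)cc1OC` — 74 nM
Compound 1 `COc1ccc(-c2cnc3nc(N)nc(N4CCN(C(=O)COc5ccccc5)CC4)c3n2)cc1OC` — 4 nM

In a functional assay on cells (T-cell, Homo sapiens) for inhibition (a lower number here means a stronger inhibitor, a higher number a weaker inhibitor), compound 1 gives 4 nM, and compound 2 gives 74 nM. Of the two numbers, compound 2 stands at the higher one, the step of a 19-fold higher number from compound 1 to compound 2 (1.27 log units; beyond the scatter) being a large one beyond the scatter. Within the data shown here, that single step is the only measured comparison in the set, and it changes the group on the carbonyl carbon, not the group on the amide-type nitrogen.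

Compound 3 `COc1ccc(-c2cnc3nc(N)nc(N4CCN(C(=O)NCc5ccc(F)cc5)CC4)c3n2)cc1OC` keeps the shared core of compound 2 and differs from it in one place: 4-fluorobenzyl in place of 4-cyanophenyl on an amide-type nitrogen. Among the measured compounds shown here, no measured step touches this position, so the direction of the change is not anchored by data. For the measured compounds named here, the piece notes only that the step from compound 1 to compound 2 shows how strongly the group beyond the carbonyl can move the numbers in this assay, so a step of similar order in either direction cannot be ruled out for compound 3. The estimate for compound 3, an expected 2.5-fold lower number from compound 2 to compound 3 (0.39 log units; beyond the scatter), is 30 nM, within 6 nM to 150 nM.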

Compound 3, half-maximal inhibitory concentration: 37 nM
Estimate against measurement, compound 3: 1.2-fold (0.09 log units) below, within the range that was stated.
By their numbers in this assay, from the lowest: compound 1; then compounds 3 and 2 (each within the scatter of the next).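

In this assay, the exchange of 4-cyanophenyl for 4-fluorobenzyl on an amide-type nitrogen is a 2.0-fold lower number from compound 2 to compound 3 (0.30 log units; within the scatter), so the nitrile-bearing and fluorine-bearing groups cannot be told apart at this position. The other new step, a 9.3-fold higher number from compound 1 to compound 3 (0.97 log units; beyond the scatter), goes the same way as a 19-fold higher number from compound 1 to compound 2 (1.27 log units; beyond the scatter), and both compounds with a substituted amino group on the carbonyl carbon therefore stand at higher numbers than compound 1 with its phenoxymethyl. Among these three compounds, the steps beyond the scatter are the two that change the group on the carbonyl carbon, whereas the step that changes only the group on the amide-type nitrogen stays within it.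

Nothing available explains why replacing phenoxymethyl with either substituted amino group gives a higher number. Also open, on these data alone, is how other groups on the amide-type nitrogen would read in this assay, such as unsubstituted benzyl, a longer phenylethyl chain or a benzyl carrying a carboxylic acid, and whether any of them would bring the number close to that of compound 1.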